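The source may report more compounds than this note shows. Statements on the series, on what has been measured and on what is new or still open speak of the compounds shown alone.

Values in a physicochemical assay for lipophilicity, read by HPLC, with a stated time of 90 min, tested at 100 uM; a higher number here means a more lipophilic compound, a lower number a more polar compound:
- compound 1 `O=C(CC1CCN(C(=O)C2CC2)CC1)Nc1ccc(OC(F)(F)F)c(F)c1`: 5.11
- compound 2 `O=C(Nc1ccc(OC(F)(F)F)cc1)NC1CCN(C(=O)[C@@H]2CCOC2)CC1`: 3.38
- compound 3 `O=C(Nc1ccc(C(F)(F)F)cc1)NC1CCN(C(=O)[C@@H]2CCOC2)CC1`: 3.27

Compound 2 at 3.38 lies within the scatter of compound 3 and well under compound 1 at 5.11. Next is compound 4 `O=C(Nc1ccc(OC(F)(F)F)cc1)NC1CCN(C(=O)c2ccoc2)CC1`, which differs from compound 2 by furan-3-yl in place of oxolan-3-yl on a carbonyl carbon, on a carbonyl carbon whose other neighbours are an amide-type nitrogen in a ring.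

For the measured compounds named here, the only measured step, a number 0.11 log units lower from compound 2 to compound 3 (within the scatter), is trifluoromethyl in place of trifluoromethoxy on an aromatic carbon. It lies at a different place and gives no direct guide. Going by the values given here, no measured step covers this change, so the expectation rests on the structural change alone. A moderate rise in this assay is expected, estimated as a number 0.42 log units higher from compound 2 to compound 4 (beyond the scatter). The estimate for compound 4 is 3.8, with a range of 3.4 to 4.3.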

Compound 4, partition coefficient: 3.63
Compound 4: middle estimate off by 0.17 log units, on the high side; the range from low to high includes it.
By their numbers in this assay, from the lowest: compounds 3, 2 and 4 (each within the scatter of the next, the first and the last beyond it); then compound 1.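

In this assay, furan-3-yl in place of oxolan-3-yl on a carbonyl carbon gives a number 0.25 log units higher from compound 2 to compound 4 (within the scatter). For the compounds shown here, this is the first reading at this position: the non-aromatic ring with its defined stereocentre gives way to an aromatic five-membered ring with no step beyond the scatter. Nothing measured here accounts for the size of this step.

Open, as far as these compounds go, is whether an amine, a carboxylic acid or a longer alkyl chain on this carbonyl carbon would give a step beyond the scatter. Also open, from the compounds shown here alone, is whether furan-3-yl gives a similar step alongside the trifluoromethyl group of compound 3.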